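This account rests on a few compounds, and the source may have more. Where it says the series, first, only, none or still open, it means among the compounds named here.

Of the compounds shown here, two have numbers so far. Compound 1, `O=C(O)Cc1sc(NC(=O)c2ccccc2)nc1-c1ccc(Cl)cc1`, is the weaker of the pair: in an in vitro assay on HEK385-7 cells for displacement of a labelled ligand from prostaglandin D2 receptor 2 (Homo sapiens) (on this read-out lower numbers stand for stronger inhibition and higher numbers for weaker inhibition), compound 1 gives 520 nM. Compound 2, `O=C(O)Cc1sc(C(c2ccc(F)cc2)c2ccc(F)cc2)nc1-c1ccc(Cl)cc1`, gives in this assay a value of 9.7 nM. Going by the values given here, of the two numbers, that of compound 2 is the lower one, and the gap between compound 1 and compound 2 lies well beyond the usual scatter; the two structures differ in more than one place, so no single step can be assigned to that gap.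

Compound 3, `COc1cc(-c2nc(C(c3ccc(F)cc3)c3ccc(F)cc3)sc2CC(=O)O)ccn1`, has not yet been measured in this assay. It differs from compound 2 in one place: 2-methoxypyridin-4-yl in place of 4-chlorophenyl on an aromatic carbon. The carboxymethyl group and the large diarylmethyl group of compound 2 are kept unchanged, so the comparison rests on the swap of one six-membered aromatic ring for another. Among the compounds with values here, nothing among the measured compounds shows how such a swap plays out here. The step the estimate implies, a 2.6-fold higher number from compound 2 to compound 3 (0.41 log units; beyond the scatter), is expected to be a modest loss, possibly within the scatter. For compound 3 the expected value in this assay is 25 nM, with a range from 6 nM to 100 nM.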

Compound 3, half-maximal inhibitory concentration: 29 nM
Compound 3: middle estimate off by 1.2-fold (0.06 log units), on the low side, and the stated range covers the measured number.
By their numbers in this assay, from the lowest: compound 2; then compound 3; then compound 1.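

Going by these compounds alone, this is the first step at this position that can be read on its own: in this assay the exchange of 4-chlorophenyl for 2-methoxypyridin-4-yl, with the carboxymethyl group and the diarylmethyl group kept unchanged, gives a 3.0-fold higher number from compound 2 to compound 3 (0.48 log units; beyond the scatter) as a modest loss. The position, an aromatic carbon next to the ring nitrogen, thus accepts a six-membered aromatic ring with a hetero atom and hydrogen-bond acceptors in place of a ring of carbon only, and compound 3 keeps a value of 29 nM in that same assay without any chlorine in the molecule. Nothing shown here speaks to what lies behind this step.

The compounds shown leave open which part of the entering group carries the step, as the ring nitrogen and the methoxy group arrive together, and a plain pyridin-4-yl or a 4-methoxyphenyl group would pull the two apart. Also open, as far as these compounds go, is how an amine or a hydroxyl group in place of the methoxy group would read, and whether the same exchange gives a step of like size on the core of compound 1.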